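Branching the alkylamino chain in a monoamine oxidase A series

A few compounds are considered here, and "the series" means these few. Any claim that something is new, unique, unknown or untested is made for them only; others in the source may bear on it.

Measured so far:
- compound 1, `CCCCNc1nnc(SCC(=O)N(Cc2cccc([N+](=O)[O-])c2)c2ccc(F)cc2)s1`: 76%
- compound 2, `CCCNc1nnc(SCC(=O)N(Cc2cccc([N+](=O)[O-])c2)c2ccc(F)cc2)s1`: 78.3%

Both compounds share the same core and differ only in the chain on the ring nitrogen. In an assay on isolated protein for inhibition of Amine oxidase [flavin-containing] A (Homo sapiens), read by fluorescence and Amplex Red, with a stated time of 30 min, tested at 10 uM (a higher number here means a stronger effect of the compound at the concentration tested, a lower number a weaker effect), compound 2 gives 78.3%, which is the higher of the two numbers, but a number 2.3 percentage points higher from compound 1 to compound 2 (within the scatter), so the two values cannot be told apart.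

Compound 3, `CC(C)CNc1nnc(SCC(=O)N(Cc2cccc([N+](=O)[O-])c2)c2ccc(F)cc2)s1`, is not yet measured in this assay. It differs from compound 2 by methyl in place of hydrogen on a saturated chain carbon bound to two saturated chain carbons. For the measured compounds named here, the only measured step, from butylamino to propylamino, concerns the length of the chain rather than a branch on it, and it was within the scatter. Going by the values given here, no measured step bears directly on a branch. A step in this assay of no size beyond the scatter is therefore expected, in either direction, and compound 3 is estimated at 75%, between 60% and 88%, a step of a number 3.3 percentage points lower from compound 2 to compound 3 (within the scatter).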

Compound 3, a percentage reported as inhibition, at one concentration (the size of the read-out at that concentration, not a potency): 72.6%
For compound 3 the middle estimate is 2.4 percentage points above the measured one; the measured number falls inside the stated range.
By their numbers in this assay, from the lowest: compounds 3, 1 and 2 (each within the scatter of the next).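

In this assay, for the compounds shown here, methyl in place of hydrogen on a saturated chain carbon bound to two saturated chain carbons gives a number 5.7 percentage points lower from compound 2 to compound 3 (within the scatter), which is the first reading of a branch on this chain. Isopropyl in place of propyl on a saturated chain carbon bound to a nitrogen on an aromatic ring gives a number 3.4 percentage points lower from compound 1 to compound 3 (within the scatter), so the butylamino, propylamino and isobutylamino chains cannot be told apart in this assay, whether the chain is branched or not. Nothing available bears on the reason for this result.

Going by these compounds, whether a shorter ethylamino chain, a cyclopropylamino group or a chain ending in a hydroxyl or an amine would give a step beyond the scatter remains open. The read-out at one concentration also leaves open whether these compounds would show a stronger or weaker effect relative to each other at any other concentration.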